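Removing one chloro from compound 1

This account rests on a few compounds, and the source may have more. Where it says the series, first, only, none or still open, it means among the compounds named here.

Three members of the series have a number or a limit so far. Compound 1 `O=C(O)/C=C/C(=O)c1ccc(Cl)cc1Cl` carries two chloro groups on its aromatic ring; compound 2 `Cc1cc(C2CCCCC2)c(C)cc1C(=O)/C=C/C(=O)O` and compound 3 `CCc1cc(CC)c(C(=O)/C=C/C(=O)O)c(CC)c1` carry alkyl groups instead. In a functional assay on LS174T cells (Homo sapiens) for inhibition, read by MTT assay, with a stated time of 72 h (on this read-out lower numbers stand for stronger inhibition and higher numbers for weaker inhibition), compound 1 gives only a limit, > 100000 nM, which is a boundary of the assay and not a number. Compound 1 is the single one of the three that sits at that boundary (the limit of > 100000 nM in this assay, at which 1 of the 3 values shown sits). Compound 2 gives 6640 nM in this assay. Compound 3 gives 7280 nM in this assay, and these two values lie within the usual scatter of each other, so no order between them can be claimed.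

Compound 4 `O=C(O)/C=C/C(=O)c1ccc(Cl)cc1` has not been measured in this assay. It differs from compound 1 in one place: hydrogen in place of chloro on an aromatic carbon.

For the measured compounds named here, no step between two measured compounds is available to guide the size of this change. With compound 1 at a limit, the step from compound 1 to compound 4 is expected to stay within the scatter, with a fair chance that compound 4 again returns only a limit. Compound 4 is therefore expected to give about 100000 nM in this assay, within a range from 30000 nM to 300000 nM. That expectation corresponds to a step of a number no higher from compound 1 to compound 4 (the limit leaves the size open).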

Compound 4, half-maximal inhibitory concentration: 28700 nM
Compound 4: middle estimate off by 3.5-fold (0.54 log units), on the high side; the measured number lies below the stated range.
By their numbers in this assay, from the lowest: compounds 2 and 3 (each within the scatter of the next); then compound 4. At a limit, above all of these: compound 1.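

Removing the chloro from the aromatic carbon ortho to a group of 7 heavy atoms gives, in this assay, an at least 3.4-fold lower number from compound 1 to compound 4 (0.54 log units; beyond the scatter). For the compounds shown here, this is the first step between two compounds that differ in one place, and it shows that this chloro can be replaced by hydrogen without loss of a measurable number: compound 4 keeps its other chloro group and still reads inside the assay range, so two chloro groups are not required for a number here. The true size of the step stays open at the upper end because the value of compound 1 is a limit and not a number: the limit of > 100000 nM in this assay, at which 1 of the 4 values shown sits.

Open, from the compounds shown here alone, is what an amine or a hydroxyl group on that same aromatic carbon would give in place of chloro or hydrogen, and whether the remaining chloro group matters to the number of compound 4. Going by these compounds alone, compound 2 and compound 3 differ from compound 4 in more than one place, so no step links the chloro-bearing members to the alkyl-bearing ones.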